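One group exchanged on the amide: compound 2 to compound 3

The source may report more compounds than this note shows. Statements on the series, on what has been measured and on what is new or still open speak of the compounds shown alone.

compound 1 `CN1C[C@H](C(=O)Nc2cccc(F)c2)[C@@H](c2ccc(/C=C/C(=O)Nc3ccccc3N)cc2)C1` gives 56 mL/min/kg
compound 2 `COc1cccc(NC(=O)[C@H]2CN(C)C[C@@H]2c2ccc(/C=C/C(=O)Nc3ccccc3N)cc2)c1` gives 65 mL/min/kg

In an in vitro ADME assay on microsomes from liver (Mus musculus) for pharmacokinetics, read by LC-MS, with a stated time of 10 min, tested at 1 uM (on this read-out lower numbers stand for slow clearance and higher numbers for fast clearance), compound 2 stands at 65 mL/min/kg and lies within the scatter of compound 1. Compound 3 `CN1C[C@H](C(=O)Nc2ccc(F)c(F)c2)[C@@H](c2ccc(/C=C/C(=O)Nc3ccccc3N)cc2)C1` differs from compound 2 by a single exchange (3,4-difluorophenyl in place of 3-methoxyphenyl on an amide-type nitrogen), with 3,4-difluorophenyl in place of 3-methoxyphenyl on an amide-type nitrogen. For the measured compounds named here, one measured step bears on this, methoxy in place of fluoro on an aromatic carbon (a 1.2-fold higher number from compound 1 to compound 2 (0.06 log units; within the scatter)), and it stayed within the scatter. Going by the values given here, no measured compound carries the 3,4-difluorophenyl group, so this evidence is thin. On that basis, the expected change in this assay is none beyond the scatter (a 1.2-fold lower number from compound 2 to compound 3 (0.07 log units; within the scatter)). Compound 3 is estimated at 55 mL/min/kg with an expected range from 32 mL/min/kg to 92 mL/min/kg in this read-out.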

Compound 3, clearance: 46 mL/min/kg
Beside the measured number, compound 3's estimate is 1.2-fold (0.08 log units) above it; the range from low to high includes it.
By their numbers in this assay, from the lowest: compounds 3, 1 and 2 (each within the scatter of the next).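

In this assay, 3,4-difluorophenyl in place of 3-methoxyphenyl on the amide-type nitrogen gives a 1.4-fold lower number from compound 2 to compound 3 (0.15 log units; within the scatter), and fluoro in place of hydrogen on an aromatic carbon gives a 1.2-fold lower number from compound 1 to compound 3 (0.09 log units; within the scatter). With compound 3, this position now holds a third aryl group, and neither the loss of the methoxy oxygen nor the addition of a second fluorine takes the clearance reading outside the scatter, so compound 1, compound 2 and compound 3 cannot be told apart here. No measurement on hand accounts for these readings.

As far as these compounds go, all three compounds carry a substituted phenyl on this nitrogen, so it remains open whether any exchange at this place can move the reading beyond the scatter. From the compounds shown here alone, how a pyridyl group, or a phenyl ring bearing an amine or a carboxylic acid, would read in this assay also remains unknown.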